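The compounds below may be only part of what the source reports. "The series", "measured", "known", "first", "only" and "open" are said of these compounds alone.

Of the compounds shown here, three with a shared core have been tested in a functional assay on K562 cells (Homo sapiens) for cytotoxicity; a higher number here means a weaker inhibitor, a lower number a stronger inhibitor. Compound 1 `CCN(CC)C(=S)SCc1ccc2nc(C)nc(O)c2c1` carries a diethylamino group on a thiocarbonyl carbon, and in this assay compound 1 gives 4400 nM. Compound 2 `Cc1nc(O)c2cc(CS/C(S)=N/C3CCCCC3)ccc2n1` gives 31000 nM in this assay, and compound 3 `Cc1nc(O)c2cc(CSC(=S)N3CCc4ccccc4C3)ccc2n1` gives 3300 nM.

Among these three numbers, compound 1 stands second highest. Its nearest neighbour is compound 3, whose number is lower by an amount that lies within the usual scatter of repeated measurements, so the two cannot be told apart. The furthest is compound 2, whose number is higher by an amount beyond that scatter, meaning compound 2 is a weaker inhibitor than compound 1.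

Compound 4 `Cc1nc(O)c2cc(CSC(=S)N3CCOCC3)ccc2n1` has not yet been measured. It differs from compound 1 in one place: morpholin-4-yl in place of diethylamino on a thiocarbonyl carbon, on a thiocarbonyl carbon whose other neighbour is sulfur. Going by the values given here, no pair of measured compounds shows this kind of change, so there is no measured step to lean on. The expected change from compound 1 to compound 4 in this assay is small, a 1.4-fold higher number from compound 1 to compound 4 (0.13 log units; within the scatter), most likely not beyond the scatter, with a slight lean towards a higher number. Compound 4 is therefore estimated at 6000 nM in this assay, within a range from 2500 nM to 15000 nM.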

Compound 4, half-maximal inhibitory concentration: 7200 nM
For compound 4 the middle estimate is 1.2-fold (0.08 log units) below the measured one; measured number inside the range.
By their numbers in this assay, from the lowest: compounds 3, 1 and 4 (each within the scatter of the next, the first and the last beyond it); then compound 2.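

In this assay the swap of the open diethylamino group for the ring of morpholin-4-yl, on a thiocarbonyl carbon whose other neighbour is sulfur, gives a 1.6-fold higher number from compound 1 to compound 4 (0.21 log units; within the scatter) and so the two compounds cannot be told apart. This is the only measured step among the compounds shown that changes just one place, and it shows that this position can take a six-membered ring with an oxygen and a hydrogen-bond acceptor, which diethylamino lacks, with no change that stands clear of the scatter. No measurement on hand bears on why the two numbers lie so close.

The compounds shown leave open whether an amine such as piperazin-1-yl, or a carboxylic acid carried on a longer chain, would keep the number in this range or move it beyond the scatter when placed on this thiocarbonyl carbon. They also leave open what the ring oxygen of morpholin-4-yl contributes on its own, a question that piperidin-1-yl, the same ring with a carbon in place of that oxygen, could address directly.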